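The source may hold more compounds than are shown below. What is called first, only, known or untested is meant among the compounds shown, and "the series" means these compounds.

Measured so far:
compound 1, `CN(Cc1cc(C(F)(F)F)cc(C(F)(F)F)c1)C(=O)[C@H]1CN(CC2CCCCC2)C[C@@H]1c1ccccc1`, 62 nM
compound 2, `CN(Cc1cc(C(F)(F)F)cc(C(F)(F)F)c1)C(=O)[C@H]1CN(C(=O)c2cnccn2)C[C@@H]1c1ccccc1`, 0.74 nM
compound 3, `CC(C)(C)OC(=O)N1C[C@H](C(=O)NCc2cc(C(F)(F)F)cc(C(F)(F)F)c2)[C@@H](c2ccccc2)C1`, 142 nM

In an assay on CHO cells for displacement of a labelled ligand from Substance-P receptor (Homo sapiens) (on this read-out higher numbers stand for weaker inhibition and lower numbers for stronger inhibition), compound 2 gives the lowest of the three numbers: compound 1 sits an 84-fold lower number from compound 1 to compound 2 (1.92 log units; beyond the scatter) away, read backwards, and compound 3 gives a still higher number, both gaps beyond the scatter. Compound 4, `CN(Cc1cc(C(F)(F)F)cc(C(F)(F)F)c1)C(=O)[C@H]1CN(C(=O)C2CCCCC2)C[C@@H]1c1ccccc1`, has not yet been measured. It differs from compound 2 in one place: cyclohexyl in place of pyrazin-2-yl on a carbonyl carbon. Among the measured compounds shown here, the only measured step that touches this part of the molecule is the one from compound 1 to compound 2, an 84-fold lower number from compound 1 to compound 2 (1.92 log units; beyond the scatter), where a (pyrazin-2-yl)carbonyl replaced a cyclohexylmethyl on the ring nitrogen. That step changed two things at once, the carbonyl and the ring, so it cannot tell how much of the gain belongs to the aromatic ring alone. Compound 4 keeps the carbonyl but loses the aromatic ring and its two hydrogen-bond acceptors, which places it structurally between compound 1 and compound 2. A step back towards compound 1 is therefore expected, but not the whole way: the expected step is a 14-fold higher number from compound 2 to compound 4 (1.13 log units; beyond the scatter). Compound 4 is estimated at 10 nM, with a range from 2 nM to 60 nM.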

Compound 4, half-maximal inhibitory concentration: 0.68 nM
Compound 4: middle estimate off by 15-fold (1.17 log units), on the high side; the whole stated range lies above it.
By their numbers in this assay, from the lowest: compounds 4 and 2 (each within the scatter of the next); then compound 1; then compound 3.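

In this assay, putting cyclohexyl in place of pyrazin-2-yl on the carbonyl carbon gives a 1.1-fold lower number from compound 2 to compound 4 (0.04 log units; within the scatter), so at this position a six-membered non-aromatic ring of carbon only, with no hydrogen-bond acceptors, reads the same as the aromatic ring with its hetero atoms. The other new step, cyclohexylcarbonyl in place of cyclohexylmethyl on the ring nitrogen, gives a 91-fold lower number from compound 1 to compound 4 (1.96 log units; beyond the scatter), and it keeps the cyclohexyl ring while changing the link to the nitrogen. Among these compounds, the large gain seen in an 84-fold lower number from compound 1 to compound 2 (1.92 log units; beyond the scatter) therefore goes with the carbonyl and does not depend on the pyrazine ring, although nothing available explains why the two rings read alike here.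

The compounds shown leave open how much of a ring the carbonyl carbon needs, since a short chain such as methyl or ethyl, or a plain phenyl ring, could read like these two or quite differently. They also leave open whether the position accepts a carboxylic acid or an amine at the end of a longer chain.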